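Methoxy to methyl on the fused aromatic ring

The source may report more compounds than this note shows. Statements on the series, on what has been measured and on what is new or still open speak of the compounds shown alone.

Measured so far:
compound 1, `Fc1cccc2c1C=C(CC1CN=CN1)CC2`: 501 nM
compound 2, `COc1cccc2c1C=C(CC1CN=CN1)CC2`: 158 nM

In an assay on isolated protein for binding affinity to Adrenergic receptor alpha-1 (Rattus norvegicus), read by radioligand binding, in the presence of a further agent that is not named here (on this read-out lower numbers stand for stronger inhibition and higher numbers for weaker inhibition), compound 2 stands lowest of the two numbers; the nearest is compound 1, with a 3.2-fold lower number from compound 1 to compound 2 (0.50 log units; beyond the scatter). Compound 3, `Cc1cccc2c1C=C(CC1CN=CN1)CC2`, is not yet measured; it differs from compound 2 by methyl in place of methoxy on an aromatic carbon. Among the measured compounds shown here, the only measured step, from compound 1 to compound 2, swaps fluoro for methoxy, so it bears on this change only indirectly: it shows the substituent at this carbon matters. Removing the oxygen while keeping a carbon is expected to give a 1.6-fold higher number from compound 2 to compound 3 (0.20 log units; within the scatter), a step likely within the scatter. Compound 3 is therefore estimated at 250 nM, between 100 nM and 630 nM.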

Compound 3, inhibition constant: 631 nM
For compound 3 the middle estimate is 2.5-fold (0.40 log units) below the measured one, and the stated range ends below it.
By their numbers in this assay, from the lowest: compound 2; then compounds 1 and 3 (each within the scatter of the next).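

In this assay, methyl in place of methoxy on this aromatic carbon gives a 4.0-fold higher number from compound 2 to compound 3 (0.60 log units; beyond the scatter) and so reverses the earlier gain seen with methoxy. Methyl and fluoro do not separate, with a 1.3-fold higher number from compound 1 to compound 3 (0.10 log units; within the scatter) as the step between them. Of the three groups, only methoxy stands apart, and its steps to both others lie beyond the scatter.

Open, as far as these compounds go, is whether a hydroxyl, an ethoxy or an amine on this carbon would track with methoxy or with methyl, and whether the oxygen itself matters. Nothing available accounts for the methoxy result.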